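Swapping the para substituent of a benzoxaborole amide

The source may report more compounds than this note shows. Statements on the series, on what has been measured and on what is new or still open speak of the compounds shown alone.

Compound 1 `O=C(CCc1cccc2c1B(O)OC2)Nc1ccc(F)cc1` gives 12000 nM in an ADME assay on WI-38 cells (Homo sapiens) for cytotoxicity, read by MTT assay, with a stated time of 72 h; a higher number here means a weaker inhibitor, a lower number a stronger inhibitor.
Compound 2 `O=C(CCc1cccc2c1B(O)OC2)Nc1ccc(Cl)cc1` gives a limit of > 100000 nM in this assay.
Compound 3 `COc1ccc(NC(=O)CCc2cccc3c2B(O)OC3)cc1` gives a limit of > 100000 nM in this assay.

Among these three, compound 1 stands as the only one with a number, since the other two values are limits of this assay rather than numbers (the limit of > 100000 nM in this assay, at which 2 of the 3 values shown sit). Compound 4 `O=C(CCc1cccc2c1B(O)OC2)Nc1ccc([N+](=O)[O-])cc1` is not yet measured. It differs from compound 1 in one place (nitro in place of fluoro on an aromatic carbon).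

Among the measured compounds shown here, two measured steps bear on this change, both starting from compound 1 and replacing the same fluoro: chloro in its place gave an at least 8.3-fold higher number from compound 1 to compound 2 (0.92 log units; beyond the scatter), and methoxy in its place gave an at least 8.3-fold higher number from compound 1 to compound 3 (0.92 log units; beyond the scatter). Both moves away from fluoro weakened the effect beyond the scatter. Nitro is a third replacement at that same aromatic carbon, so a step of similar direction is expected, most likely ending at a limit. For compound 4 the expected step is a 6.7-fold higher number from compound 1 to compound 4 (0.82 log units; beyond the scatter), giving an estimate of 80000 nM with a range from 20000 nM to 300000 nM.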

Compound 4, half-maximal inhibitory concentration: > 100000 nM
Compound 4: only a limit was reported; the forecaster's own chance of this, stated with the estimate: 60%; middle value at least 1.2-fold (0.09 log units) from the limit.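

Nitro in place of fluoro gives an at least 8.3-fold higher number from compound 1 to compound 4 (0.92 log units; beyond the scatter), so a third replacement at this aromatic carbon moves the same way as chloro and methoxy did. Fluoro is therefore the only one of the four groups here that goes with a real number in this assay, and the steps among compound 2, compound 3 and compound 4 cannot be read. All three of those compounds end at the same limit of the assay, not at numbers: the limit of > 100000 nM in this assay, at which 3 of the 4 values shown sit.

As far as these compounds go, how far compound 2, compound 3 and compound 4 lie beyond that limit stays unknown, so chloro, methoxy and nitro cannot be put in any order. From the compounds shown here alone, whether a plain hydrogen, an amine or a carboxylic acid at this carbon would give a number like that of compound 1 or another limit also remains open.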